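Notes on the side chain exchange from compound 2 to compound 3

The source may report more compounds than this note shows. Statements on the series, on what has been measured and on what is new or still open speak of the compounds shown alone.

Two measured compounds frame this series. Compound 1 `CC(C)n1nc(-c2ccccc2)c(-c2ccccc2)cc1=O` and compound 2 `CCCCCCCNc1cc(-c2ccccc2)c(-c2ccccc2)nn1` were tested in an assay on microsomes from liver for inhibition of sterol O-acyltransferase 1 (Rattus norvegicus); on this read-out higher numbers stand for weaker inhibition and lower numbers for stronger inhibition. In this assay compound 1 gives 152000 nM. Compound 2 gives 55000 nM, the lowest of the two numbers; the gap to compound 1 lies beyond the scatter. Among the measured compounds shown here, no further measured pair differs in a single place, so no step size has been established.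

Compound 3 `CCCCCC[S+]([O-])c1cc(-c2ccccc2)c(-c2ccccc2)nn1` is not yet measured. It differs from compound 2 by a group of 8 heavy atoms (6 carbon, 1 oxygen, 1 sulfur; no ring) in place of a group of 8 heavy atoms (7 carbon, 1 nitrogen; no ring), on an aromatic carbon. Nothing measured here tells how this exchange acts. The expected step for compound 3 is a 1.6-fold higher number from compound 2 to compound 3 (0.21 log units; within the scatter), a small move toward weaker inhibition, not clearly beyond the scatter. Compound 3 is estimated at 90000 nM, within 30000 nM to 270000 nM.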

Compound 3, half-maximal inhibitory concentration: 75000 nM
Beside the measured number, compound 3's estimate is 1.2-fold (0.08 log units) above it; the measured number falls inside the stated range.
By their numbers in this assay, from the lowest: compounds 2 and 3 (each within the scatter of the next); then compound 1.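

In this assay, the exchange of heptylamino on this aromatic carbon for the side chain of compound 3, which carries sulfur and oxygen, gives a 1.4-fold higher number from compound 2 to compound 3 (0.13 log units; within the scatter) and so does not separate the two compounds on this read-out. Among the compounds shown here, this is the first single-place step, and it shows that at this position, with the same count of heavy atoms, the loss of the hydrogen-bond donor of heptylamino leaves no difference beyond the scatter. Nothing available gives a reason for this outcome.

Open, going by these compounds, is whether the chain or the linking atom matters more here, since both change at once in this exchange. A hexylthio group with no oxygen on the sulfur, a longer chain on the nitrogen, or a carboxylic acid at the chain end would each address a part of that question.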